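From a piperidinyl carbonyl to a methylphenyl triazole

The source may report more compounds than this note shows. Statements on the series, on what has been measured and on what is new or still open speak of the compounds shown alone.

Measured in an ADME assay on HeLa cells (Homo sapiens) for cytotoxicity, read by MTT assay; on this read-out lower numbers stand for stronger inhibition and higher numbers for weaker inhibition:
- compound 1 `COc1ccc(C[C@H]2COC(=O)[C@@H]2Cc2ccc(OCc3cn(-c4ccc(F)cc4)nn3)c(OC)c2)cc1OC` gives >= 600000 nM, a limit of the assay and not a number
- compound 2 `COc1ccc(C[C@H]2COC(=O)[C@@H]2Cc2ccc(OCc3cn(-c4ccc(Br)cc4)nn3)c(OC)c2)cc1OC` gives 128000 nM
- compound 3 `COc1ccc(C[C@H]2COC(=O)[C@@H]2Cc2ccc(OCC(=O)N3CCCCC3)c(OC)c2)cc1OC` gives 293000 nM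

Of the two true numbers, compound 3 holds the higher one, 293000 nM. Its nearest neighbour is compound 2, and the gap is a 2.3-fold higher number from compound 2 to compound 3 (0.36 log units; beyond the scatter).

Compound 4 `COc1ccc(C[C@H]2COC(=O)[C@@H]2Cc2ccc(OCc3cn(-c4ccc(C)cc4)nn3)c(OC)c2)cc1OC` keeps the shared core and carries 1-(4-methylphenyl)-1H-1,2,3-triazol-4-yl in place of (piperidin-1-yl)carbonyl on a saturated chain carbon bound to an oxygen on an aromatic ring.

Two measured steps exchange the same positions with a related triazole, and they point in opposite directions. One is an at least 2.0-fold lower number from compound 1 to compound 3 (0.31 log units; beyond the scatter), and the other is the gap already given. The difference between the triazoles themselves is also sizeable, at an at least 4.6-fold lower number from compound 1 to compound 2 (0.67 log units; beyond the scatter). Among the measured compounds shown here, no compound with the methyl group has been measured, so its number could fall anywhere around these values. A middle course between the fluoro and bromo compounds is therefore the fair expectation. The expected change is a 1.2-fold lower number from compound 3 to compound 4 (0.07 log units; within the scatter), which means no step beyond the scatter is expected. For compound 4 the estimated value is 250000 nM, with an expected range from 100000 nM to 600000 nM.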

Compound 4, half-maximal inhibitory concentration: >= 600000 nM
Compound 4 ended at the assay's limit (the forecaster's own chance of this, stated with the estimate: 25%); middle value at least 2.4-fold (0.38 log units) away from the limit.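

In this assay, compound 4 gives >= 600000 nM, which is a limit of the assay and not a number. Placing 1-(4-methylphenyl)-1H-1,2,3-triazol-4-yl on this saturated chain carbon bound to an oxygen on an aromatic ring, in place of (piperidin-1-yl)carbonyl, gives an at least 2.0-fold higher number from compound 3 to compound 4 (0.31 log units; beyond the scatter), so a second aryl triazole now lies on the weaker side of the piperidine amide, as compound 1 already did, while compound 2 goes against this. Methyl in place of bromo on an aromatic carbon gives an at least 4.6-fold higher number from compound 2 to compound 4 (0.67 log units; beyond the scatter), which shows that among these three triazoles the bromo compound alone gives a true number, and that the outer aromatic substituent can move the read-out in either direction from the amide.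

The step from compound 1 to compound 4 cannot be read, because both compounds end at the same limit: the limit of >= 600000 nM in this assay, at which 2 of the 4 values shown sit. Whether the stronger inhibition goes with bromo alone stays open, since the compounds shown do not include a chloro or iodo group on that aromatic carbon, nor an amine or carboxylic acid there.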